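The compounds below may be only part of what the source reports. "The series", "measured", "known", "first", "only" and "open" are said of these compounds alone.

Of the compounds shown here, three have been measured in an assay on RBL-1 cells with Polyunsaturated fatty acid 5-lipoxygenase (Rattus norvegicus) as the target; a lower number here means a stronger inhibitor, a higher number a weaker inhibitor. Compound 1 `COc1ccc2c(O)c(Cc3ccccc3)ccc2c1` gives 1900 nM in this assay, compound 2 `Cc1cc(Cc2ccccc2)c(O)c2ccccc12` gives 20 nM in this assay, and compound 3 `CC(c1ccccc1)c1ccc2ccccc2c1O` gives 70 nM in this assay. Compound 2 therefore stands lowest of the three numbers and is the strongest inhibitor of the set: its nearest neighbour is compound 3, whose number lies beyond the scatter above it, and compound 1 is the furthest, well beyond the scatter. Compound 1 and compound 2 differ in more than one place, so their two values show only that the two patterns are far apart.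

Compound 4 `CCOC(=O)c1cc(Cc2ccccc2)c(O)c2ccccc12` has not been measured. It differs from compound 2 in one place: ethoxycarbonyl in place of methyl on an aromatic carbon. Among the compounds with values here, no pair of measured compounds shares this change, so the size and direction of the step cannot be read from a matched step. The ethoxycarbonyl group is larger than the methyl it replaces and brings two hydrogen-bond acceptors, and an exchange of this kind is more often followed by a loss than by a gain in this assay. Compound 4 is accordingly expected to give about 80 nM in this assay, within a range from 15 nM to 600 nM. The expected step of a 4.0-fold higher number from compound 2 to compound 4 (0.60 log units; beyond the scatter) is thus a moderate move toward a weaker inhibitor, somewhat beyond the scatter.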

Compound 4, half-maximal inhibitory concentration: 160 nM
The estimate for compound 4 lay 2.0-fold (0.30 log units) below the measured number; measured number inside the range.
By their numbers in this assay, from the lowest: compound 2; then compound 3; then compound 4; then compound 1.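

In this assay, within the data shown here, the exchange of methyl for ethoxycarbonyl on the aromatic carbon para to the hydroxy group gives an 8.0-fold higher number from compound 2 to compound 4 (0.90 log units; beyond the scatter), the first change that can be read at a single place. The step shows that this position is not indifferent to what it carries, yet that a group much larger than methyl does not abolish inhibition there, since compound 4 still gives 160 nM. No measurement shown here ties the step to any particular feature of the ethoxycarbonyl group.

Going by these compounds, a single step cannot separate the effect of the larger group as a whole from that of its carbonyl, so it remains open whether a carboxylic acid, a primary amide or a plain ethyl chain on this carbon would give a number nearer that of compound 2 or that of compound 4. On these data alone, it also remains open whether the same exchange would move the number in the same direction on the core of compound 3.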